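A single aryl swap from compound 2 to compound 3

The source may report more compounds than this note shows. Statements on the series, on what has been measured and on what is new or still open speak of the compounds shown alone.

Of the compounds shown here, two have been tested so far. Compound 1 (`COc1ccc(C2=C(c3cc(OC)c(OC)c(OC)c3)CC3CCCN3C2=O)cc1O`) gives > 100000 nM in a functional assay on NCI-H520 cells (Homo sapiens) for cytotoxicity (a higher number here means a weaker inhibitor of growth, a lower number a stronger inhibitor of growth), and this value is a limit of the assay, not a number. For the measured compounds named here, compound 2 (`CSc1ccc(C2=C(c3ccc(F)c(F)c3)C(=O)N3CCCC3C2)cc1`) gives 200 nM in this assay and this is the only actual number available.

Compound 3 (`COc1ccc(C2=C(c3ccc(SC)cc3)CC3CCCN3C2=O)cc1`) has not yet been measured. It departs from compound 2 at one place, with 4-methoxyphenyl in place of 3,4-difluorophenyl on a double-bonded ring carbon. The 4-(methylsulfanyl)phenyl group stays in place. Going by the values given here, no measured pair shows a change of this kind, and compound 2 at 200 nM is the only anchor. No step beyond the usual scatter is therefore expected in this assay in either direction. The expected step of a 1.3-fold lower number from compound 2 to compound 3 (0.12 log units; within the scatter) stays within that scatter. In this assay compound 3 is estimated at 150 nM with an expected range from 30 nM to 1500 nM.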

Compound 3, concentration for 50% growth inhibition: 800 nM
Compound 3: the middle estimate sits 5.3-fold (0.73 log units) below what was measured; the measured number falls inside the stated range.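

In this assay, the position on the double-bonded ring carbon now has its first readable change: 4-methoxyphenyl in place of 3,4-difluorophenyl gives a 4.0-fold higher number from compound 2 to compound 3 (0.60 log units; beyond the scatter). This step lies beyond the scatter, so the identity of the aryl group at this position matters, even though the two groups match in heavy atom count and each has one six-membered aromatic ring of carbon only. Compound 1 adds no number to set beside this step, as its value is a limit of the assay: the limit of > 100000 nM in this assay, at which 1 of the 3 values shown sits.

The compounds shown leave open how a 4-fluorophenyl or a plain phenyl group would read at this place, and so whether the higher number goes with losing the two fluorines or with gaining the methoxy group. They also leave open how an amine or a carboxylic acid on this aryl ring would read.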